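Adding a Hydroxy Group to the Bare Ring of Compound 2

A few compounds are considered here, and "the series" means these few. Any claim that something is new, unique, unknown or untested is made for them only; others in the source may bear on it.

Of the compounds shown here, three built on one shared core have been measured: compound 1 `O=C(N/N=C/c1ccc(-c2ccccc2)cc1)c1cnccn1`, compound 2 `O=C(N/N=C/c1ccccc1)c1cnccn1` and compound 3 `O=C(N/N=C/c1ccc(F)cc1)c1cnccn1`. In a functional assay on the whole organism (Abdomen, strain Swiss) for inhibition, with Mus musculus as the target, with stated times of 40 min and 25 min, at a dose of 100 umol/kg by the oral route (a lower number here means less inhibition, a higher number more inhibition at the dose given (going by the name of the read-out)), compound 1 gives 57.3%, compound 2 gives 42.4% and compound 3 gives 74.5%. Compound 2, whose outer ring carries no group at all, stands lowest of the three: a number 14.9 percentage points lower from compound 1 to compound 2 (beyond the scatter), and a number 32.1 percentage points higher from compound 2 to compound 3 (beyond the scatter). Between the two substituted compounds, a number 17.2 percentage points higher from compound 1 to compound 3 (beyond the scatter).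

Compound 4 `O=C(N/N=C/c1ccccc1O)c1cnccn1` differs from compound 2 in one place: hydroxy in place of hydrogen on an aromatic carbon. For the measured compounds named here, the steps that bear on this are the two that add a group to the bare ring of compound 2; both raised the number, one by a large amount and one modestly. Neither of them involves a hydroxy group, and neither sits in the same place, so the expectation is loose. A modest rise is expected, a number 12.6 percentage points higher from compound 2 to compound 4 (beyond the scatter). Compound 4 is therefore estimated at 55%, within a range from 35% to 75%.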

Compound 4, a percentage reported as inhibition, in the whole organism at one dose (the size of the read-out at that dose, not a potency): 73.1%
The estimate for compound 4 lay 18.1 percentage points below the measured number, and the stated range covers the measured number.
By their numbers in this assay, from the lowest: compound 2; then compound 1; then compounds 4 and 3 (each within the scatter of the next).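

In this assay, hydroxy in place of hydrogen gives a number 30.7 percentage points higher from compound 2 to compound 4 (beyond the scatter) and so counts as a large rise, the first shown for a group ortho to a large group on the outer ring. A group at this position is therefore compatible with a higher number than the bare ring of compound 2 gives, and the change need not be fluoro or phenyl to raise it. Nothing measured here explains why this step is so large.

The compounds shown leave open whether the rise belongs to hydroxy itself or would also come with a methoxy group, an amine or a chlorine atom in the same place. They also leave open what hydroxy would do on the other carbons of that ring.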